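Compound 3 to compound 4: a step from the limit

A few compounds are considered here, and "the series" means these few. Any claim that something is new, unique, unknown or untested is made for them only; others in the source may bear on it.

In an ADME assay on L02 cells (Homo sapiens) for cytotoxicity, read by MTT assay, with a stated time of 24 h (a lower number here means a stronger inhibitor, a higher number a weaker inhibitor), compound 1 `COc1cc(/C=C/c2ccc(OCc3ccc(C(F)(F)F)cc3)cc2)cc(OC)c1` gives > 100000 nM as a limit of the assay, not a number. Compound 2 `C=CCCCOc1ccc(/C=C/c2cc(OC)cc(OC)c2)cc1` gives > 100000 nM as a limit too. Compound 3 `COCCOc1ccc(/C=C/c2cc(OC)cc(OC)c2)cc1` gives > 100000 nM as a limit as well, so its standing is known only as that limit. The evidence so far is the limit of > 100000 nM in this assay, at which 3 of the 3 values shown sit, and no measured number exists in the series.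

Compound 4 `COc1cc(/C=C/c2ccc(OCC(=O)NCc3ccccc3)cc2)cc(OC)c1` has benzylcarbamoyl in place of methoxymethyl on a saturated chain carbon bound to an oxygen on an aromatic ring is the change to follow.

Among the compounds with values here, three measured steps bear on it: a step that the two limits leave unreadable from compound 1 to compound 3 and a step that the two limits leave unreadable from compound 1 to compound 2 and a step that the two limits leave unreadable from compound 2 to compound 3 offer no size to carry over. Within the data shown here, compound 1 is the nearest precedent for a chain ending in an aromatic ring, and a step that the two limits leave unreadable from compound 1 to compound 3 shows no readable change.

The expected size of a number no higher from compound 3 to compound 4 (the limit leaves the size open) is nothing beyond the scatter, in neither direction, and a further report of only a limit is the likeliest result. The estimated value for compound 4 is 100000 nM with an expected range of 40000 nM to 200000 nM if a number is reported at all.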

Compound 4, half-maximal inhibitory concentration: > 100000 nM
Compound 4: only a limit was reported; the forecaster's own chance of this, stated with the estimate: 80%; the middle value sits exactly at the limit.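

No step can be read among compound 1, compound 2, compound 3 and compound 4, since each result is a limit of the assay and not a number: the limit of > 100000 nM in this assay, at which 4 of the 4 values shown sit.

The compounds shown leave open whether any of these chain changes shifts the half-maximal inhibitory concentration, and by how much.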